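Chloro in Place of Amino on the Shared Core

The source may report more compounds than this note shows. Statements on the series, on what has been measured and on what is new or still open speak of the compounds shown alone.

Compound 1 `ClCc1ccc(Cn2cnc3c(Cl)ncnc32)cc1`: 57500 nM
Compound 2 `Nc1nc(Cl)c2ncn(Cc3ccc(CCl)cc3)c2n1`: > 100000 nM, a limit of the assay
Compound 3 `ClCc1cccc(Cn2cnc3c(Cl)nc(Cl)nc32)c1`: 27500 nM

In a functional assay on A498 cells (Homo sapiens) for cytotoxicity, read by sulforhodamine B assay, with a stated time of 48 h (on this read-out lower numbers stand for higher toxicity in this test and higher numbers for lower toxicity in this test), compound 1 gives 57500 nM and compound 3 gives 27500 nM. Compound 2 reaches only the limit of the assay, > 100000 nM (the limit of > 100000 nM in this assay, at which 1 of the 3 values shown sits). Compound 4 `ClCc1ccc(Cn2cnc3c(Cl)nc(Cl)nc32)cc1` differs from compound 2 by chloro in place of amino on an aromatic carbon. Among the measured compounds shown here, the one measured step that bears on this is an at least 1.7-fold higher number from compound 1 to compound 2 (0.24 log units; that floor lies within the scatter), which runs the other way and ends at the limit. Removing the amino is expected to bring the number back toward compound 1, whose value is 57500 nM, and compound 3, which also carries two chloro groups on the core, gives 27500 nM. Compound 4 is therefore expected at 40000 nM (range 15000 nM to 100000 nM), an estimated at least 2.5-fold lower number from compound 2 to compound 4 (0.39 log units; beyond the scatter).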

Compound 4, concentration lethal to 50% of the cells: 52500 nM
For compound 4 the middle estimate is 1.3-fold (0.12 log units) below the measured one, within the range that was stated.
By their numbers in this assay, from the lowest: compounds 3, 4 and 1 (each within the scatter of the next, the first and the last beyond it). At a limit, above all of these: compound 2.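

Putting chloro in place of amino on an aromatic carbon between two ring nitrogen atoms gives an at least 1.9-fold lower number from compound 2 to compound 4 (0.27 log units; that floor lies within the scatter) in this assay. Compound 2 stands at a limit, so the true size of this step cannot be read: the limit of > 100000 nM in this assay, at which 1 of the 4 values shown sits.

Chloro in place of hydrogen at the same position gives a 1.1-fold lower number from compound 1 to compound 4 (0.04 log units; within the scatter), so here the chloro group and the hydrogen cannot be told apart in this read-out.

What the compounds shown leave open is how a methoxy group or a methylamino group at this position would read, and whether either would stand with compound 1 and compound 4 or reach a limit like compound 2.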